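Title: From Ethyl to tert-Butyl on the Aniline Ring

A few compounds are considered here, and "the series" means these few. Any claim that something is new, unique, unknown or untested is made for them only; others in the source may bear on it.

These three compounds share one amide core and differ only in the group on the aniline side. Compound 1 `Cc1cccc(NC(=O)c2cc(F)cc(C#N)c2)c1` carries a methyl there and in an in vitro functional assay on HEK293-A cells for antagonist activity at metabotropic glutamate receptor 5 (Rattus norvegicus), read by calcium flux (on this read-out lower numbers stand for stronger inhibition and higher numbers for weaker inhibition), compound 1 gives 122 nM. Compound 2 `N#Cc1cc(F)cc(C(=O)Nc2cccc(C(F)(F)F)c2)c1` carries a trifluoromethyl, and in this assay compound 2 gives 543 nM. Compound 3 `CCc1cccc(NC(=O)c2cc(F)cc(C#N)c2)c1` carries an ethyl, and in this assay compound 3 gives 4940 nM, the highest of the three numbers, meaning the weakest inhibition. The step of a 40-fold higher number from compound 1 to compound 3 (1.61 log units; beyond the scatter) is large, and a 9.1-fold higher number from compound 2 to compound 3 (0.96 log units; beyond the scatter) is smaller but still clear; a 4.5-fold higher number from compound 1 to compound 2 (0.65 log units; beyond the scatter) is modest.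

Compound 4 `CC(C)(C)c1cccc(NC(=O)c2cc(F)cc(C#N)c2)c1` goes one size further: tert-butyl in place of ethyl on an aromatic carbon. Among the measured compounds shown here, the steps that bear on it are those in which the group on this carbon grew, above all a 40-fold higher number from compound 1 to compound 3 (1.61 log units; beyond the scatter), where a single added carbon raised the number sharply, and a 9.1-fold higher number from compound 2 to compound 3 (0.96 log units; beyond the scatter). With two more carbons added at the same place, a further rise in the number is expected, so that a 3.0-fold higher number from compound 3 to compound 4 (0.48 log units; beyond the scatter) is anticipated, although the measurement may simply report a limit if the compound falls outside the range of this assay. For compound 4 the expected value is 15000 nM, with a range from 4000 nM to 60000 nM.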

Compound 4, half-maximal inhibitory concentration: > 30000 nM
Compound 4 ended at the assay's limit; the forecaster's own chance of this, stated with the estimate: 35%; middle value at least 2.0-fold (0.30 log units) from the limit.
By their numbers in this assay, from the lowest: compound 1; then compound 2; then compound 3. At a limit, above all of these: compound 4.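

The reading for compound 4 is a limit of the assay and not a number, so each step to it gives only a minimum size: the limit of > 30000 nM in this assay, at which 1 of the 4 values shown sits.

Even so, the change from ethyl to tert-butyl gives an at least 6.0-fold higher number from compound 3 to compound 4 (0.78 log units; beyond the scatter), which shows that the rise seen from methyl to ethyl does not level off or reverse with the larger group, and among the three alkyl groups shown, the number climbs with each enlargement on this aromatic carbon. The gaps to the two compounds with lower numbers are wider, with an at least 55-fold higher number from compound 2 to compound 4 (1.74 log units; beyond the scatter) and an at least 240-fold higher number from compound 1 to compound 4 (2.39 log units; beyond the scatter), so methyl and trifluoromethyl are both far better accepted at this place than tert-butyl, and the trifluoromethyl of compound 2 sits well apart from the tert-butyl of compound 4.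

From the compounds shown here alone, how far beyond the limit compound 4 really lies stays unknown, so the true sizes of these steps remain open. Also open, going by these compounds, is how a chlorine atom, a methoxy group, a cyclopropyl ring or a small amine on this carbon would compare with the methyl of compound 1.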